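The compounds below may be only part of what the source reports. "The series", "measured", "known", "first", "only" and "open" are said of these compounds alone.

Measured so far in a functional assay on cells (Cancer cell lines, Homo sapiens) for inhibition; on this read-out lower numbers stand for stronger inhibition of growth and higher numbers for weaker inhibition of growth:
Compound 1 `N=C(N)N/N=C/c1c(-c2cc(Cl)sc2Cl)nc2n1CCS2`: 12300 nM
Compound 2 `N=C(N)N/N=C/c1c(-c2ccsc2)nc2sccn12`: 17400 nM
Compound 3 `Cc1cn2c(/C=N/NC(=N)N)c(-c3cccs3)nc2s1`: 5750 nM

Each number is the concentration needed to halve cell growth, so a smaller number marks a stronger compound. In this small set, compound 1 with 12300 nM lies within the usual scatter of compound 2. Compound 3 gives a lower number, and that gap to compound 1 lies beyond the scatter.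

Compound 4 `Cc1cc(-c2nc3n(c2/C=N/NC(=N)N)CCS3)c(C)s1` has not been measured yet. It keeps the core of compound 1, with 2,5-dimethylthiophen-3-yl in place of 2,5-dichlorothiophen-3-yl on an aromatic carbon.

Going by the values given here, the measured compounds differ from one another in more than one place, so no measured step shows what this swap does. Among the compounds with values here, the only guide is the spread of the three numbers, which runs from compound 3 at 5750 nM to compound 2 at 17400 nM. A value for compound 4 inside that spread seems the most reasonable expectation, and the estimate is centred close to compound 1. In this assay, the expected 1.2-fold lower number from compound 1 to compound 4 (0.09 log units; within the scatter) stays within the scatter. For compound 4 the estimated value is 10000 nM, with an expected range from 4500 nM to 22000 nM.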

Compound 4, concentration for 50% growth inhibition: 24000 nM
Compound 4: middle estimate off by 2.4-fold (0.38 log units), on the low side; measured number outside the range, above it.
By their numbers in this assay, from the lowest: compound 3; then compounds 1, 2 and 4 (each within the scatter of the next).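

Going by these compounds alone, this is the first pair in the set that differs in one place only, so the swap of 2,5-dichlorothiophen-3-yl for 2,5-dimethylthiophen-3-yl on the core of compound 1 can now be read directly: in this assay, the step is a 2.0-fold higher number from compound 1 to compound 4 (0.29 log units; within the scatter). For this position, on an aromatic carbon next to the ring nitrogen, the pair therefore shows no change in growth inhibition that can be told apart from the normal spread of repeated measurements, even though the two chlorine atoms give way to two methyl groups. Nothing given here offers an explanation of this result, whether in binding or in any measured property of the two groups.

The compounds shown leave open whether a group of a different kind at this position, such as a phenyl ring, an amine or a carboxylic acid, would shift the number beyond the scatter. They also leave open whether a thiophene carrying only one chlorine or one methyl would behave like compound 1 and compound 4, since this single pair changes both substituents together.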